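The source may hold more compounds than are shown below. What is called first, only, known or untested is meant among the compounds shown, and "the series" means these compounds.

Compound 3 `CC(C)CN1CCCN(CCn2ccc3ccc(Br)cc32)CC1` gives 95% in an assay on HEK293 cells for binding affinity to 5-hydroxytryptamine receptor 7 (Homo sapiens), read by radioligand binding, tested at 1 uM (on this read-out higher numbers stand for more inhibition at the one concentration tested (going by the name of the read-out) and lower numbers for less inhibition), the highest of the three numbers; compound 1 `CN1CCCN(CCn2ccc3ccc(C(F)(F)F)cc32)CC1` with 89% lies within the scatter of it, while compound 2 `CN1CCCN(CCn2ccc3ccc(OCc4ccccc4)cc32)CC1` with 28% lies well beyond it. Among the compounds with values here, the one measured step, a number 61 percentage points lower from compound 1 to compound 2 (beyond the scatter), concerns a substituent on an aromatic carbon of the shared core. Compound 4 `Brc1ccc2ccn(CCN3CCCN(c4ccccc4)CC3)c2c1` differs from compound 3 by phenyl in place of isobutyl on an amine nitrogen in a ring. Within the data shown here, no measured step touches that nitrogen, so neither direction nor size can be read from the numbers; the two compounds with high inhibition keep a small alkyl there, and nothing shows what a phenyl does. The expected step is a number 15 percentage points lower from compound 3 to compound 4 (beyond the scatter), with a wide range. Compound 4 is therefore estimated at 80%, between 45% and 98%.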

Compound 4, a percentage reported as inhibition, at one concentration (the size of the read-out at that concentration, not a potency): 18%
Compound 4: middle estimate off by 62 percentage points, on the high side; the measured number lies below the stated range.
By their numbers in this assay, from the lowest: compounds 4 and 2 (each within the scatter of the next); then compounds 1 and 3 (each within the scatter of the next).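

On this assay, the amine nitrogen in the seven-membered ring proves sensitive to its substituent: phenyl in place of isobutyl gives a number 77 percentage points lower from compound 3 to compound 4 (beyond the scatter). Within the data shown here, this is the first measured change at this nitrogen, and it shows that the position does not accept every group. Nothing available explains the drop.

On these data alone, whether the loss follows from the aromatic ring or from the larger group stays open; cyclohexyl or benzyl on this nitrogen would separate the two. As far as these compounds go, whether the step holds with trifluoromethyl on the core also remains open.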